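A Benzyl Swap and What It May Cost in Potency

A few compounds are considered here, and "the series" means these few. Any claim that something is new, unique, unknown or untested is made for them only; others in the source may bear on it.

Going by the values given here, compound 1 `OC[C@H]1O[C@@H](n2cnc3c(NCc4ccc(Cl)c(Cl)c4)ncnc32)[C@H](O)[C@@H]1O` is the only member of this set with a measured number: in a functional assay on K562 cells (Homo sapiens) for antiproliferative activity, with a stated time of 72 h (on this read-out higher numbers stand for weaker inhibition and lower numbers for stronger inhibition), compound 1 gives 10800 nM. Compound 2 `OC[C@H]1O[C@@H](n2cnc3c(NCc4cc(F)cc(F)c4)ncnc32)C(O)C1O` reaches only a limit of the assay, > 166000 nM in this assay. Compound 3 `COc1cc(CNc2ncnc3c2ncn3[C@@H]2O[C@H](CO)[C@@H](O)[C@H]2O)cc(OC)c1O` likewise stops at a limit, > 166000 nM in this assay. The picture is the limit of > 166000 nM in this assay, at which 2 of the 3 values shown sit, so compound 1 stands alone with a real reading. Compound 4 `OC[C@H]1O[C@@H](n2cnc3c(NCc4cccc(C(F)(F)F)c4)ncnc32)[C@H](O)[C@@H]1O` is not yet measured; it differs from compound 1 by 3-(trifluoromethyl)phenyl in place of 3,4-dichlorophenyl on a saturated chain carbon bound to a nitrogen on an aromatic ring. Among the compounds with values here, no step between two measured compounds differing in one place exists here, so the size of this change is uncertain. It is expected to cost some potency, a step of a 2.3-fold higher number from compound 1 to compound 4 (0.36 log units; beyond the scatter) in this assay. Compound 4 is therefore estimated at 25000 nM, within 6000 nM to 120000 nM.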

Compound 4, half-maximal inhibitory concentration: > 166000 nM
Compound 4 was reported as a limit; the forecaster's own chance of this, stated with the estimate: 25%; middle value at least 6.6-fold (0.82 log units) away from the limit.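

Going by these compounds alone, putting 3-(trifluoromethyl)phenyl in place of 3,4-dichlorophenyl on a saturated chain carbon bound to a nitrogen on an aromatic ring gives an at least 15-fold higher number from compound 1 to compound 4 (1.18 log units; beyond the scatter), the first step that can be read at this position, and it is large. The reading of compound 4 is a limit, not a number. Compound 1 now stands even more alone among the compounds shown: the limit of > 166000 nM in this assay, at which 3 of the 4 values shown sit.

On these data alone, what remains open is whether any other group at this position keeps a measurable reading. A phenyl ring carrying a single chlorine, an amine or a carboxylic acid could each be set against compound 1.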